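A few compounds are considered here, and "the series" means these few. Any claim that something is new, unique, unknown or untested is made for them only; others in the source may bear on it.

Compound 1, `CC(=O)N[C@@H](C)C(=O)NCc1ccc(OCc2cccc(F)c2)cc1`, gives 100 mg/kg in a functional assay on the whole organism (strain albino) for inhibition, with Mus musculus as the target, in the maximal electroshock model, with a stated time of 0.5 h; a higher number here means that more compound is needed for the effect, a lower number that less compound is needed.
Compound 2, `CC(=O)N[C@H](C)C(=O)NCc1ccc(OCc2cccc(F)c2)cc1`, reaches only the limit of > 30 mg/kg in this assay, not a number.
Compound 3, `CC(=O)N[C@@H](C(=O)NCc1ccc(OCc2cccc(F)c2)cc1)C(C)C`, likewise reaches only the limit of > 300 mg/kg in this assay.

For the measured compounds named here, compound 3 thus stands at a limit: the reading shows only that more compound than that amount is needed, and two of the three values shown are limits of this kind rather than numbers.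

Compound 4, `CC(=O)N[C@@H](C(=O)NCc1ccc(OCc2cccc(F)c2)cc1)C(C)(C)C`, has not yet been measured. It differs from compound 3 in one place: methyl in place of hydrogen on a saturated chain carbon bound to three saturated chain carbons.

Going by the values given here, two measured steps bear on this change. Enlarging the side chain from 1-acetamidoethyl to 1-acetamido-2-methylpropyl gave an at least 3.0-fold higher number from compound 1 to compound 3 (0.47 log units; beyond the scatter). The closely related step that the two limits leave unreadable from compound 2 to compound 3 cannot be read, since the limit of > 30 mg/kg in this assay, at which 1 of the 3 values shown sits, and the limit of > 300 mg/kg in this assay, at which 1 of the 3 values shown sits, hide its size, and a step that the limit leaves unreadable from compound 1 to compound 2 is likewise hidden by the limit of > 30 mg/kg in this assay, at which 1 of the 3 values shown sits, together with the fact that compounds 1 and 2 differ only in the configuration as drawn. Among the compounds with values here, the one readable step points upward as the side chain grows, and compound 4 grows it further.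

Compound 4 is therefore expected to need at least as much as compound 3, with a fair chance that this assay again reports only a limit. The expected step is a step that the limit leaves unreadable from compound 3 to compound 4. Compound 4 is estimated at 600 mg/kg, within a range from 250 mg/kg to 2000 mg/kg.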

Compound 4, dose for half-maximal effect: > 300 mg/kg
Compound 4: a limit, no number; the forecaster's own chance of this, stated with the estimate: 80%; the middle value is on the limit's open side.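

In this assay compound 4 gives only a limit, > 300 mg/kg, and not a number. Exchanging 1-acetamidoethyl for 1-acetamido-2,2-dimethylpropyl gives an at least 3.0-fold higher number from compound 1 to compound 4 (0.47 log units; beyond the scatter), so tert-butyl on this carbon, like the isopropyl of compound 3, needs more compound than the methyl of compound 1. The steps to compound 4 from compound 3 and from compound 2 cannot be read, so the added methyl that turns isopropyl into tert-butyl has no readable size here, and compound 3 and compound 4 both stop at one limit: the limit of > 300 mg/kg in this assay, at which 2 of the 4 values shown sit.

On these data alone, whether tert-butyl needs more compound than isopropyl, less, or about the same remains open, since neither compound has a number. Also open, as far as these compounds go, is how a side chain of another kind on this carbon, such as an aminomethyl group, a carboxylic acid or a longer straight chain, would read, and whether the drawn configuration of the tert-butyl compound matters.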